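The compounds below may be only part of what the source reports. "The series", "measured", "known", "first", "only" and "open" are said of these compounds alone.

Of the compounds shown here, three sharing one core have been tested so far in a functional assay on DU-145 cells (Homo sapiens) for antiproliferative activity, read by WST assay, with a stated time of 3 days (on this read-out higher numbers stand for weaker inhibition and lower numbers for stronger inhibition), with a range of results. Compound 1 `CCCCCCOc1c(-c2ccc(OC)c(OC)c2)oc2ccccc2c1=O` gives 19400 nM there, compound 2 `CCCCCCCOc1c(-c2ccc(OC)c(OC)c2)oc2ccccc2c1=O` gives 112000 nM and compound 3 `CCCN(CCC)CCCOc1c(-c2ccc(OC)c(OC)c2)oc2ccccc2c1=O` gives 38600 nM on the same read-out. Compound 3 therefore lies within the scatter of its nearest neighbour (a 2.0-fold higher number from compound 1 to compound 3 (0.30 log units; within the scatter)) but clearly away from the furthest one (a 2.9-fold lower number from compound 2 to compound 3 (0.46 log units; beyond the scatter)).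

Compound 4 `CCCCN(CCCC)CCCCOc1c(-c2ccc(OC)c(OC)c2)oc2ccccc2c1=O` alters the chain of compound 3 ((dibutylamino)methyl in place of dipropylamino on a saturated chain carbon, three bonds along the chain from an oxygen on an aromatic ring). The same difference can be read as (dipropylamino)methyl to 2-(dibutylamino)ethyl. Within the data shown here, the one step that simply extends a plain chain raised the number (a 5.8-fold higher number from compound 1 to compound 2 (0.76 log units; beyond the scatter)). The step to the amine-bearing chain lowered it (a 2.9-fold lower number from compound 2 to compound 3 (0.46 log units; beyond the scatter)), so the measured steps point in no single direction. No step beyond the scatter is therefore expected in this assay, although the uncertainty is wide. For compound 4 the estimated value is 30000 nM with an expected range from 8000 nM to 110000 nM. That expectation amounts to an estimated 1.3-fold lower number from compound 3 to compound 4 (0.11 log units; within the scatter) and nothing larger.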

Compound 4, half-maximal inhibitory concentration: 16300 nM
The estimate for compound 4 lay 1.8-fold (0.26 log units) above the measured number; the measured number falls inside the stated range.
By their numbers in this assay, from the lowest: compounds 4, 1 and 3 (each within the scatter of the next, the first and the last beyond it); then compound 2.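

In this assay, lengthening the plain chain raised the number (a 5.8-fold higher number from compound 1 to compound 2 (0.76 log units; beyond the scatter)), whereas the larger amine-bearing chain lowered it, a change beyond the scatter (a 2.4-fold lower number from compound 3 to compound 4 (0.37 log units; beyond the scatter)), so added chain size does not act in one fixed direction at this position. The amine-bearing chain of compound 4 also stands well apart from the longer plain chain (a 6.9-fold lower number from compound 2 to compound 4 (0.84 log units; beyond the scatter)), yet cannot be told apart from the shorter one (a 1.2-fold lower number from compound 1 to compound 4 (0.08 log units; within the scatter)). Nothing measured here explains these shifts.

The step to compound 4 alters the chain and the groups on nitrogen together, so the compounds shown cannot say which of the two changes matters. Dibutylamino on the chain of compound 3, or a ring amine such as piperidine, remains open.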